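The source may report more compounds than this note shows. Statements on the series, on what has been measured and on what is new or still open speak of the compounds shown alone.

Compound 1 `CCn1c(SCC(=O)Nc2ccc(C(C)=O)cc2)nnc1-c1ccc(OC)c(OC)c1` was tested in a functional assay on the whole organism (strain albino) for inhibition, with Rattus norvegicus as the target, read by paw edema, with stated times of 30 min and 1 h, at a dose of 0.28 mmol/kg by the oral route (a higher number here means more inhibition at the dose given (going by the name of the read-out), a lower number less inhibition), and gave 56%. Compound 3 `CCn1c(SCC(=O)Nc2ccc(C(C)=O)cc2)nnc1-c1ccc(OC)cc1` differs from it in one place, (hydrogen in place of methoxy on an aromatic carbon), and in this assay compound 3 gives 51%; the step of a number 5 percentage points lower from compound 1 to compound 3 (within the scatter) lies within the scatter. Compound 2 `C=CCn1c(SCC(=O)Nc2ccc(/C(C)=N/O)cc2)nnc1-c1ccc(OC)c(OC)c1` carries a different core; how the cores of compound 1 and compound 2 differ is not broken down here. In this assay compound 2 gives 53%, a number within the scatter of both compound 1 and compound 3. Compound 4 `C=CCn1c(SCC(=O)Nc2ccc(/C(C)=N/O)cc2)nnc1-c1ccc(OC)cc1` has not yet been measured in this assay. It arises from compound 2 by hydrogen in place of methoxy on an aromatic carbon, the same change as that made from compound 1 to compound 3, at a place described in the same words. Because a number 5 percentage points lower from compound 1 to compound 3 (within the scatter) stayed within the scatter, a similarly small step is expected here, estimated as a number 5 percentage points lower from compound 2 to compound 4 (within the scatter). On this basis compound 4 is expected to give about 48% in this assay, with the expected range running from 38% to 58%.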

Compound 4, a percentage reported as inhibition, in the whole organism at one dose (the size of the read-out at that dose, not a potency): 54%
Estimate against measurement, compound 4: 6 percentage points below, within the range that was stated.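

In this assay the change from 3,4-dimethoxyphenyl to 4-methoxyphenyl gives a number 1 percentage points higher from compound 2 to compound 4 (within the scatter). Set beside the same change on the core of compound 1, the new step does not differ from the earlier one: the same change on two cores in this assay, a number 5 percentage points lower (within the scatter) from compound 1 to compound 3 and a number 1 percentage points higher (within the scatter) from compound 2 to compound 4, 6 percentage points apart, within the scatter of two such steps On these two cores, then, the change carries over as a step too small to read at this one dose, but this does not show that it would stay as small on a third core, and it gives no measure of potency, as a single dose reports only the size of the effect at that dose.

The compounds shown leave open how the inhibition of paw edema responds when the remaining methoxy group gives way to an amine or a carboxylic acid. They also leave open whether the change behaves alike on a core that carries a longer chain, and how these compounds compare at other doses.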